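The source may report more compounds than this note shows. Statements on the series, on what has been measured and on what is new or still open speak of the compounds shown alone.

Compound 1 `COc1ccc(NC(=O)c2cccc(Nc3ncc(F)c(Nc4ccc(F)cc4)n3)c2)cc1` gives > 10000 nM in a functional assay on KB cells (Homo sapiens) for antiproliferative activity, read by sulforhodamine B assay, with a stated time of 3 days (on this read-out lower numbers stand for stronger inhibition of growth and higher numbers for weaker inhibition of growth), a limit of the assay rather than a number.
Compound 2 `O=C(Nc1cccc(Nc2ncc(F)c(Nc3ccc(F)cc3)n2)c1)c1ccncc1` gives 5280 nM in this assay.
Compound 3 `O=C(Nc1cccc(Nc2ncc(F)c(Nc3ccc(F)cc3)n2)c1)c1ccccc1` gives > 10000 nM in this assay, again a limit.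

Compound 1 therefore stands only at the limit of > 10000 nM in this assay, at which 2 of the 3 values shown sit, with no number of its own. Compound 4 `COCC(=O)Nc1cccc(Nc2ncc(F)c(Nc3ccc(F)cc3)n2)c1` differs from it by ((methoxymethyl)carbonyl)amino in place of (4-methoxyphenyl)carbamoyl on an aromatic carbon. Within the data shown here, no measured step swaps an aromatic amide for a chain of this kind; the nearest comparisons are an at least 1.8-fold lower number from compound 1 to compound 2 (0.27 log units; that floor lies within the scatter) and an at least 1.8-fold higher number from compound 2 to compound 3 (0.27 log units; that floor lies within the scatter), both of which only reach a floor within the scatter, while a step that the two limits leave unreadable from compound 1 to compound 3. With compound 1 at a limit, compound 4 is expected to stay weak, and the step of an at least 1.2-fold lower number from compound 1 to compound 4 (0.09 log units; that floor lies within the scatter) is an estimate made with little to lean on. Compound 4 is expected to give about 8000 nM, within 2500 nM to 30000 nM.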

Compound 4, concentration for 50% growth inhibition: 6250 nM
Compound 4: middle estimate off by 1.3-fold (0.11 log units), on the high side; the range from low to high includes it.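

With methoxymethyl in place of pyridin-4-yl on the carbonyl carbon, the result is a 1.2-fold higher number from compound 2 to compound 4 (0.07 log units; within the scatter) and so a chain with no ring gives a number that cannot be told apart from that of the aromatic ring at this position. The steps of an at least 1.6-fold lower number from compound 1 to compound 4 (0.20 log units; that floor lies within the scatter) and an at least 1.6-fold lower number from compound 3 to compound 4 (0.20 log units; that floor lies within the scatter) give floors only and do not pass the scatter. They start from limits, not numbers: the limit of > 10000 nM in this assay, at which 2 of the 4 values shown sit.

Still open, going by these compounds, is whether an amine, a carboxylic acid or a longer chain on that carbonyl carbon would give a clearly lower number than compound 2 and compound 4 share.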